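Replacing morpholin-4-yl on a thiocarbonyl carbon

The source may report more compounds than this note shows. Statements on the series, on what has been measured and on what is new or still open speak of the compounds shown alone.

In a functional assay on MGC-803 cells (Homo sapiens) for inhibition, read by CCK-8 assay, with a stated time of 48 h (on this read-out higher numbers stand for weaker inhibition and lower numbers for stronger inhibition), compound 3 (`COc1ccc(CN(C(=O)CSC(=S)N2CCOCC2)c2cc(OC)c(OC)c(OC)c2)cc1`) gives 2370 nM as the highest of three numbers. Compound 1 (`COc1ccc(CN(C(=O)CSc2nc3ccccc3o2)c2cc(OC)c(OC)c(OC)c2)cc1`) stands at 450 nM and compound 2 (`COc1ccc(CN(C(=O)CSC(=S)N2CCN(C(=O)OC(C)(C)C)CC2)c2cc(OC)c(OC)c(OC)c2)cc1`) at 310 nM on the same read-out. Compound 4 (`COc1ccc(CN(C(=O)CSC(=S)N2CCc3cc(OC)ccc32)c2cc(OC)c(OC)c(OC)c2)cc1`) differs from compound 3 by 5-methoxy-2,3-dihydro-1H-indol-1-yl in place of morpholin-4-yl on a thiocarbonyl carbon and so gains a six-membered aromatic ring of carbon only.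

Among the measured compounds shown here, one measured step bears on this directly: a 5.3-fold higher number from compound 1 to compound 3 (0.72 log units; beyond the scatter) as a group holding such a ring gave way to a six-membered non-aromatic ring with 2 hetero atoms. Compound 2 goes against any simple reading, since it has no such ring in that place, yet its number is lower than that of compound 3. Both neighbours still suggest that compound 3 sits high, so a move of similar size toward a lower number is expected. The expected change is a 4.7-fold lower number from compound 3 to compound 4 (0.68 log units; beyond the scatter) on this estimate. The estimated value for compound 4 is 500 nM within an expected range from 100 nM to 2000 nM in this assay.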

Compound 4, half-maximal inhibitory concentration: 11700 nM
The estimate for compound 4 lay 23-fold (1.37 log units) below the measured number; measured number outside the range, above it.
By their numbers in this assay, from the lowest: compounds 2 and 1 (each within the scatter of the next); then compound 3; then compound 4.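

At the thiocarbonyl carbon, 5-methoxy-2,3-dihydro-1H-indol-1-yl in place of morpholin-4-yl gave a 4.9-fold higher number from compound 3 to compound 4 (0.69 log units; beyond the scatter) in this assay, so the added six-membered aromatic ring of carbon only did not bring the lower number that a 5.3-fold higher number from compound 1 to compound 3 (0.72 log units; beyond the scatter) had seemed to tie to such a ring. A ring of this kind therefore does not by itself mark stronger inhibition among these compounds: compound 1 holds one in its group on a sulfur and sits low, whereas compound 4 holds one in its group on the thiocarbonyl carbon and sits highest of the four. Nothing available gives a reason for this change.

As far as these compounds go, whether piperidin-1-yl or diethylamino on the thiocarbonyl carbon would fall nearer compound 2 or compound 4 stays open. Also open, from the compounds shown here alone, is whether the methoxy group or the fused ring system carries the change, a question that unsubstituted 2,3-dihydro-1H-indol-1-yl would address.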